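The source may hold more compounds than are shown below. What is called first, only, known or untested is meant among the compounds shown, and "the series" means these compounds.

In an ADME assay on the whole organism (plasma) for pharmacokinetics, with Rhesus monkey (Macaca mulatta) as the target, read by LC-MS, at a dose of 1 mg/kg by the oral route (on this read-out lower numbers stand for lower exposure and higher numbers for higher exposure at the dose given), compound 1 (`COc1ccc2nc(COc3ccc(CC(C(N)=O)[S+](C)[O-])cc3)n(C)c2c1`) gives 36.7 ng.h/mL and is the lowest of the three numbers in hand. Compound 2 (`O=C1NC(=O)C(Cc2ccc(OCc3nc4ccc(O)cc4[nH]3)cc2)S1`) gives 85.4 ng.h/mL as the next number up, and compound 3 (`COc1ccc2nc(COc3ccc(CC4SC(=O)NC4=O)cc3)[nH]c2c1`) gives 2300 ng.h/mL as the highest. Compound 4 (`COc1ccc2nc(COc3ccc(CC(C(N)=O)S(C)(=O)=O)cc3)n(C)c2c1`) keeps the core of compound 1 and carries methylsulfonyl on a saturated chain carbon bound to a carbonyl carbon and a saturated chain carbon (a group of 4 heavy atoms (1 carbon, 2 oxygen, 1 sulfur; no ring) in place of a group of 3 heavy atoms (1 carbon, 1 oxygen, 1 sulfur; no ring), on a saturated chain carbon bound to a carbonyl carbon and a saturated chain carbon). Going by the values given here, only one measured step is available, a 27-fold higher number from compound 2 to compound 3 (1.43 log units; beyond the scatter) for methyl in place of hydrogen on an oxygen on an aromatic ring. That step is large, but it is a different change at another place, so it gives no direction for the change at hand. Among the compounds with values here, it shows only that a single change can move this assay a long way in this set. Within the data shown here, no measured pair tests methylsulfonyl. No step beyond the scatter is therefore expected, with a wide range left open in either direction. For compound 4 the estimated value is 40 ng.h/mL with an expected range from 10 ng.h/mL to 160 ng.h/mL on this read-out. This estimate means a 1.1-fold higher number from compound 1 to compound 4 (0.04 log units; within the scatter) as the expected step.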

Compound 4, area under the concentration-time curve: 27 ng.h/mL
Compound 4: middle estimate off by 1.5-fold (0.17 log units), on the high side; the measured number falls inside the stated range.
By their numbers in this assay, from the lowest: compounds 4 and 1 (each within the scatter of the next); then compound 2; then compound 3.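

At the saturated chain carbon bound to a carbonyl carbon and a saturated chain carbon, methylsulfonyl in place of the group of 3 heavy atoms gives a 1.4-fold lower number from compound 1 to compound 4 (0.13 log units; within the scatter) in this assay. On the core of compound 1, this exchange therefore does not separate the two compounds on this read-out, whereas the change at the other place, a 27-fold higher number from compound 2 to compound 3 (1.43 log units; beyond the scatter), showed that a single change can move the number a long way. No measurement is available that explains why the two numbers lie so close together.

As far as these compounds go, whether a different group at this saturated chain carbon, such as an amine, a carboxylic acid or a longer chain, would produce a step beyond the scatter remains open. Also open is whether methylsulfonyl would give a step of similar size on a structure other than the core of compound 1, since the only pair that tests this group is the one shown here.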